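A few compounds are considered here, and "the series" means these few. Any claim that something is new, unique, unknown or untested is made for them only; others in the source may bear on it.

Measured so far:
- compound 1 `CSc1ccc(C(=O)/C=C/c2ccc([N+](=O)[O-])s2)cc1`: 8560 nM
- compound 2 `COc1ccc(/C=C/C(=O)c2cccc(I)c2)cc1`: > 50000 nM

In an ADME assay on THP-1 cells (Homo sapiens) for cytotoxicity, read by resazurin assay, with a stated time of 72 h (a lower number here means that less compound is tolerated, a higher number that more compound is tolerated), compound 1 gives 8560 nM. Compound 2 gives only a limit, not a number, at > 50000 nM; this is the limit of > 50000 nM in this assay, at which 1 of the 2 values shown sits. Compound 3 `COc1ccc(/C=C/C(=O)c2cccc(Br)c2)cc1` has not yet been measured. It differs from compound 2 by bromo in place of iodo on an aromatic carbon. For the measured compounds named here, no measured pair shows this change, so in this assay no step beyond the usual scatter is expected in either direction. Compound 3 is therefore estimated at 50000 nM, with a range from 20000 nM to 100000 nM. The expected step is a number no higher from compound 2 to compound 3 (the limit leaves the size open), which is expected to stay within the scatter.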

Compound 3, half-maximal cytotoxic concentration: > 50000 nM
Compound 3: no number, only a limit; the forecaster's own chance of this, stated with the estimate: 75%; the middle value sits exactly at the limit.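

Compound 2 and compound 3 both give only a limit rather than a number, so no step between them can be read: the limit of > 50000 nM in this assay, at which 2 of the 3 values shown sit.

The compounds shown leave open whether bromo and iodo on this aromatic carbon differ at all in this assay.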